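The source may hold more compounds than are shown below. What is called first, only, known or untested is meant among the compounds shown, and "the series" means these compounds.

Measured so far in a functional assay on SEM cells (Homo sapiens) for antiproliferative activity, with a stated time of 72 h; on this read-out higher numbers stand for an effect only at larger amounts of compound and lower numbers for an effect already at smaller amounts:
- compound 1, `COc1ccc(-c2cc(=O)c3c(OC)cc(OC)cc3n2C)cc1`: 26000 nM
- compound 2, `COc1ccc(-c2cc(=O)c3c(OC)cc(OC)cc3n2Cc2ccccc2)cc1`: the result is a limit of the assay, > 17300 nM
- compound 3, `COc1ccc(-c2cc(=O)c3c(OC)cc(OC)cc3n2S(=O)(=O)c2ccc([N+](=O)[O-])cc2)cc1`: "not determined" (no result reported)

Compound 3 therefore stands without a number of its own. Of the two results that exist, one is a plain value and one is only a limit, as the limit of > 17300 nM in this assay, at which 1 of the 3 values shown sits, shows. Within the data shown here, the one step between measured compounds, a step that the limit leaves unreadable from compound 1 to compound 2, cannot be read in size.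

Compound 4, `COc1ccc(-c2cc(=O)c3c(OC)cc(OC)cc3n2S(=O)(=O)c2ccc(C#N)cc2)cc1`, differs from compound 3 by cyano in place of nitro on an aromatic carbon. Among the measured compounds shown here, no measured step concerns a change of this kind, and no measured step concerns the group on the aromatic nitrogen that compounds 3 and 4 share. For the measured compounds named here, the only guidance is that the two compounds with the same shared core that were measured act only at large amounts. Compound 4 is therefore expected to act only at large amounts too, with an estimated value of 20000 nM, between 4000 nM and 80000 nM, and a fair chance that this assay again reports only a limit.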

Compound 4, half-maximal effective concentration: 1300 nM
Compound 4: the middle estimate sits 15-fold (1.19 log units) above what was measured, outside the stated range (below it).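

In this assay the group on the aromatic nitrogen proves to matter: (4-cyanophenyl)sulfonyl in place of methyl gives a 20-fold lower number from compound 1 to compound 4 (1.30 log units; beyond the scatter) and in place of benzyl gives an at least 13-fold lower number from compound 2 to compound 4 (1.12 log units; beyond the scatter). The result for compound 2 is a limit and not a number, so that second step has only a minimum size: the limit of > 17300 nM in this assay, at which 1 of the 4 values shown sits. Among these compounds, this is the first change at this position whose effect can be read, and compound 4 acts at clearly smaller amounts than compound 1.

The steps from compound 1 to compound 2 and from compound 3 to compound 4 cannot be read, so nitro and cyano remain uncompared. From the compounds shown here alone, whether the sulfonyl link or the cyano carries the change stays open, and a methylsulfonyl on the nitrogen or an amine in place of the cyano would help separate the two.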